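The source may report more compounds than this note shows. Statements on the series, on what has been measured and on what is new or still open speak of the compounds shown alone.

Measured so far in a functional assay on SMMC-7721 cells (Homo sapiens) for cytotoxicity, read by MTT assay, with a stated time of 72 h; on this read-out higher numbers stand for weaker inhibition and lower numbers for stronger inhibition:

- compound 1 `COc1ccc2c(c1)[n+]([O-])nc(NCOC(C)c1ccccc1)[n+]2[O-]`: 740 nM
- compound 2 `O=[N+]([O-])c1cccc(COCNc2n[n+]([O-])c3ccccc3[n+]2[O-])c1`: 520 nM
- compound 3 `COCNc1n[n+]([O-])c2ccccc2[n+]1[O-]`: 2480 nM

All three compounds share one core carrying a short chain through an oxygen. Compound 3 is the smallest of them, with a methyl at the end of that chain, and in this assay compound 3 gives the highest number of the three: its number lies beyond the usual scatter above both compound 1 and compound 2, so it is the weakest inhibitor of the set. Compound 4 `[O-][n+]1nc(NCOCc2ccccc2)[n+]([O-])c2ccccc21` has not yet been measured. It differs from compound 3 in one place: phenyl in place of hydrogen on a saturated chain carbon bound to an oxygen on a saturated carbon. The same difference, cut one bond further out, reads methyl to benzyl. Since compound 1 gives 740 nM and compound 2 gives 520 nM, both with a ring at the end of the chain, the expectation is that the step of a 3.5-fold lower number from compound 3 to compound 4 (0.55 log units; beyond the scatter) lowers the number well beyond the scatter. For compound 4 the estimated value in this assay is 700 nM, in a range from 350 nM to 1500 nM.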

Compound 4, half-maximal inhibitory concentration: 4790 nM
Estimate against measurement, compound 4: 6.8-fold (0.84 log units) below; the whole stated range lies below it.
By their numbers in this assay, from the lowest: compounds 2 and 1 (each within the scatter of the next); then compounds 3 and 4 (each within the scatter of the next).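

In this assay, phenyl in place of hydrogen on a saturated chain carbon bound to an oxygen on a saturated carbon gives a 1.9-fold higher number from compound 3 to compound 4 (0.29 log units; within the scatter) and so, at this position, methyl to benzyl brings no change that can be told from the usual scatter. A ring at the end of the chain is therefore not enough on its own: hydrogen in place of nitro on an aromatic carbon gives a 9.2-fold higher number from compound 2 to compound 4 (0.96 log units; beyond the scatter) and this single change on the ring separates the two compounds clearly. Nothing shown here accounts for either step.

Still open, as far as these compounds go, is whether the nitro group is special, or whether an amine or a carboxylic acid on that aromatic carbon would also separate from compound 4. A longer chain in place of the methyl of compound 3 also remains to be seen.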